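Cytotoxicity notes on the series: compound 2 to compound 3

The source may report more compounds than this note shows. Statements on the series, on what has been measured and on what is new or still open speak of the compounds shown alone.

Compound 1 `Cc1cc(N2CCN(C)CC2)c2ncc(CSCCc3ccccc3)n2c1` carries the shared core but has no result in an ADME assay on HEL cells (Homo sapiens) for cytotoxicity, with a stated time of 3 days; on this read-out lower numbers stand for higher toxicity in this test and higher numbers for lower toxicity in this test; in this assay compound 1 is recorded only as "not determined" (no result reported). Among the compounds with values here, compound 2 `Cc1cc(N2CCCC2=O)c2ncc(CSCCc3ccccc3)n2c1` is therefore the one compound with a number: in this assay compound 2 gives 20 ug/mL, and this stands as the sole reference point of the series, with no second measured compound to set a step against.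

Compound 3 `Cc1cc(-n2ccc3cccnc32)c2ncc(CSCCc3ccccc3)n2c1` differs from compound 2 in one place: a group of 9 heavy atoms (7 carbon, 2 nitrogen; one five-membered aromatic ring with 1 hetero atom, one six-membered aromatic ring with 1 hetero atom) in place of a group of 6 heavy atoms (4 carbon, 1 nitrogen, 1 oxygen; one five-membered non-aromatic ring with 1 hetero atom), on an aromatic carbon. The group that leaves is the 2-oxopyrrolidin-1-yl; the group that enters has no common name and sits on an aromatic carbon of the six-membered aromatic ring with 1 nitrogen, ortho to a fused ring and meta to the methyl group.

Within the data shown here, no step between measured compounds is available, so the size of any change in this assay is unanchored. For compound 3 the expected step is a 1.7-fold lower number from compound 2 to compound 3 (0.22 log units; within the scatter), in the direction of greater toxicity, though a result within the scatter would not surprise. For compound 3 the estimated value in this assay is 12 ug/mL, with a range from 4 ug/mL to 40 ug/mL, and a limit instead of a number remains possible.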

Compound 3, minimum cytotoxic concentration: 100 ug/mL
Estimate against measurement, compound 3: 8.3-fold (0.92 log units) below, and the stated range ends below it.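

Within the data shown here, replacing the 2-oxopyrrolidin-1-yl on this aromatic carbon, ortho to a fused ring and meta to a methyl group, gives the first readable step in this assay, and it is a 5.0-fold higher number from compound 2 to compound 3 (0.70 log units; beyond the scatter), towards lower toxicity in this test. This shows that the read-out responds to what sits at this position, and that a two-ring aromatic group here does not push the series towards greater toxicity, at least in this one comparison. Nothing at hand accounts for the shift.

Compound 1 remains at "not determined" (no result reported), so this single step is the only measure of the position, and it changes several things at once: the ring count, the aromatic character and the loss of the carbonyl, with no compound shown to separate them. From the compounds shown here alone, whether a plain phenyl, which would keep one aromatic ring without the fused partner, or a carboxylic acid at the same aromatic carbon would move the number in the same direction stays open, as does whether the step holds in any test other than this cytotoxicity read-out.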